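Bromo for fluoro on the aryl ring: compound 3 to compound 4

The source may report more compounds than this note shows. Statements on the series, on what has been measured and on what is new or still open speak of the compounds shown alone.

Measured so far in a functional assay on MKN-45 cells (Homo sapiens) for cytotoxicity, read by MTT assay, with a stated time of 72 h; on this read-out lower numbers stand for stronger inhibition and higher numbers for weaker inhibition:
compound 1, `COc1cc2c(Oc3ccc(NC(=O)c4nn(-c5ccc(Br)cc5)c(=O)c5ccccc45)cc3F)ccnc2cc1OCCCN1CCCC1`, gives 230 nM
compound 2, `COc1cc2c(Oc3ccc(NC(=O)c4nn(-c5ccc(Br)cc5)c(=O)c5ccccc45)cc3F)ccnc2cc1OCCCN1CCN(C)CC1`, gives 350 nM
compound 3, `COc1cc2c(Oc3ccc(NC(=O)c4nn(-c5ccc(F)cc5)c(=O)c5ccccc45)cc3F)ccnc2cc1OCCCN1CCC(C)CC1`, gives 130 nM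

Compound 3 stands at the lowest of the three numbers in this assay. The gap to compound 1 is within the usual scatter, so no order between those two can be claimed. The gap to compound 2 is beyond the scatter.

Going by the values given here, the one measured step, a 1.5-fold higher number from compound 1 to compound 2 (0.18 log units; within the scatter), concerns the amine at the end of the chain and stays within the scatter.

Compound 4, `COc1cc2c(Oc3ccc(NC(=O)c4nn(-c5ccc(Br)cc5)c(=O)c5ccccc45)cc3F)ccnc2cc1OCCCN1CCC(C)CC1`, differs from compound 3 by bromo in place of fluoro on an aromatic carbon. Among the compounds with values here, no measured pair isolates this exchange: compounds 1 and 2 carry the bromo group, but each also carries a different amine than compound 3, so their numbers mix two changes. The halogen exchange on its own is therefore untested here. With nothing to point in either direction, the expected step is none beyond the scatter, a 1.3-fold higher number from compound 3 to compound 4 (0.12 log units; within the scatter), and the range is kept wide to cover the two-change comparisons. For compound 4 in this assay the estimate is 170 nM, between 60 nM and 450 nM.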

Compound 4, half-maximal inhibitory concentration: 330 nM
For compound 4 the middle estimate is 1.9-fold (0.29 log units) below the measured one, within the range that was stated.
By their numbers in this assay, from the lowest: compounds 3, 1, 4 and 2 (each within the scatter of the next, the first and the last beyond it).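

Bromo in place of fluoro on this aromatic carbon, para to a large group, is now isolated in this assay with the 4-methylpiperidin-1-yl amine held fixed, and the change from 4-fluorophenyl to 4-bromophenyl gives a 2.5-fold higher number from compound 3 to compound 4 (0.40 log units; beyond the scatter), a modest step but the first single change in the series to lie beyond the scatter. Going by these compounds alone, with bromo held fixed, the amine at the chain end still shows no separation, as both a 1.1-fold lower number from compound 2 to compound 4 (0.03 log units; within the scatter) and a 1.4-fold higher number from compound 1 to compound 4 (0.16 log units; within the scatter) stay within the scatter, so in these compounds the halogen exchange is the only single change with a readable effect. No measured property of these compounds bears on the halogen step.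

The compounds shown leave open whether the step from fluoro to bromo carries over to the pyrrolidin-1-yl and 4-methylpiperazin-1-yl amines, and where chloro or methoxy on that aromatic carbon would fall relative to the two halogens. Also open, on these data alone, is whether a morpholine at the chain end, or a longer chain, would separate from the three amines seen so far.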